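Swapping Ethoxy for Dimethylamino: What to Expect

The source may report more compounds than this note shows. Statements on the series, on what has been measured and on what is new or still open speak of the compounds shown alone.

Measured compounds:
- compound 1, `CCOC(=O)c1cc(CCCOc2c(C)cc(-c3noc(C(F)(F)F)n3)cc2C)on1`, in an ADME assay on HeLa cells (Homo sapiens) for cytotoxicity, read by crystal violet staining, with a stated time of 72 h (a lower number here means that less compound is tolerated, a higher number that more compound is tolerated), gives 17200 nM.
- compound 3, `Cc1cc(-c2noc(C(F)(F)F)n2)cc(C)c1OCCCc1cc(C(=O)N(C)C)no1`, in this assay gives 13200 nM.
- compound 2, `CCOC(=O)c1cc(CCCOc2ccc(-c3noc(C(F)(F)F)n3)cc2)on1`, in this assay gives only a limit, > 100000 nM.

Compound 1 and compound 3 share a core and differ in one place: dimethylamino in place of ethoxy on a carbonyl carbon. That change made a 1.3-fold lower number from compound 1 to compound 3 (0.11 log units; within the scatter), so the two values sit within the scatter of each other and no direction can be read from them.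

Compound 2 has a different core from compound 1; the difference between the two cores is not broken down here. For compound 2 the value in this assay is a limit of the assay, not a number, a point at which one of the three values here sits (the limit of > 100000 nM in this assay, at which 1 of the 3 values shown sits).

Compound 4, `CN(C)C(=O)c1cc(CCCOc2ccc(-c3noc(C(F)(F)F)n3)cc2)on1`, is not yet measured. It stands to compound 2 as compound 3 stands to compound 1: dimethylamino in place of ethoxy on a carbonyl carbon, the same change at the same kind of position. The step from compound 2 to compound 4 in this assay is expected to be about a step that the limit leaves unreadable from compound 2 to compound 4, because a 1.3-fold lower number from compound 1 to compound 3 (0.11 log units; within the scatter) showed no movement beyond the scatter on the other core. Compound 4 is therefore estimated at 120000 nM, between 40000 nM and 300000 nM, and most likely the assay will again report only a limit.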

Compound 4, half-maximal cytotoxic concentration: 28000 nM
Compound 4: the middle estimate sits 4.3-fold (0.63 log units) above what was measured, and the stated range ends above it.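

On the core of compound 2, putting dimethylamino in place of ethoxy on a carbonyl carbon gave an at least 3.5-fold lower number from compound 2 to compound 4 (0.55 log units; beyond the scatter) in this assay, so here the swap moved the read-out clearly, and toward less compound being tolerated. The same change therefore cannot simply be carried over at the same size from one core to the other, since the two steps do not match: the same change on two cores in this assay, a 1.3-fold lower number (0.11 log units; within the scatter) from compound 1 to compound 3 and an at least 3.5-fold lower number (0.55 log units; beyond the scatter) from compound 2 to compound 4, at least 2.7-fold (0.43 log units) apart, beyond the scatter of two such steps

The value of compound 2, > 100000 nM, is a limit and not a number, so the full size of its step remains unknown, and two pairs of compounds give neither a reason for the gap nor a rule for any third core.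

The compounds shown leave open how other groups on that carbonyl carbon would behave on the two cores, such as a carboxylic acid, a methylamino group or an ester with a longer chain in place of ethoxy. They also leave open which part of the difference between the two cores goes with the larger step, since a single swap on each core cannot separate that out.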